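Swapping One Small Aromatic Ring for Another

The source may report more compounds than this note shows. Statements on the series, on what has been measured and on what is new or still open speak of the compounds shown alone.

Compound 1 `Cc1ccncc1-c1ccc2[nH]c(=O)nc(-c3ccccc3)c2c1` — > 50000 nM
Compound 2 `O=c1nc(-c2ccccc2)c2cc(-c3cnc4ccccc4c3)ccc2[nH]1` — > 50000 nM

In an ADME assay on THP-1 cells (Homo sapiens) for cytotoxicity, read by MTT assay, with a stated time of 72 h (a lower number here means that less compound is needed, a higher number that more compound is needed for the effect), compound 1 gives > 50000 nM, which is a limit of the assay rather than a measured number. Compound 2 likewise sits at a limit: in this assay compound 2 gives > 50000 nM. Compound 1 therefore stands at the limit of > 50000 nM in this assay, at which 2 of the 2 values shown sit, so nothing separates it from the one other compound shown. Within the data shown here, no step between measured compounds is available, and nothing beyond the shared limit is known.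

Compound 3 `Cn1nccc1-c1ccc2[nH]c(=O)nc(-c3ccccc3)c2c1` differs from compound 1 in one place: 1-methyl-1H-pyrazol-5-yl in place of 4-methylpyridin-3-yl on an aromatic carbon. Because both measured compounds rest at the limit of > 50000 nM in this assay, at which 2 of the 2 values shown sit, the step from compound 1 to compound 3 is expected to be none beyond the scatter, so a step that the limit leaves unreadable from compound 1 to compound 3 is the expected change. Compound 3 is therefore estimated to give 60000 nM in this assay, within a range of 30000 nM to 120000 nM, most likely reported only as a limit.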

Compound 3, half-maximal effective concentration: > 50000 nM
Compound 3 gave a limit, no number; the forecaster's own chance of this, stated with the estimate: 80%; the middle value lies beyond the limit too.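

Compound 1 and compound 3 both give a limit of the assay rather than a number, so the step between them cannot be read: the limit of > 50000 nM in this assay, at which 3 of the 3 values shown sit.

Going by these compounds, how much of each compound the effect would take, and whether compound 1, compound 2 and compound 3 differ at all in this assay, stays open.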